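The compounds below may be only part of what the source reports. "The series", "measured", "known", "first", "only" and "open" are said of these compounds alone.

Of the compounds shown here, two of the shared core have been measured in an assay on brain for displacement of a labelled ligand from 5-hydroxytryptamine receptor 4 (Cavia porcellus), with a stated time of 30 min, in the presence of a further agent that is not named here; on this read-out higher numbers stand for weaker inhibition and lower numbers for stronger inhibition. Compound 1 `COc1ccc(S(=O)(=O)NCCN2CCC(CCC(=O)c3cc(Cl)c(N)cc3OC)CC2)cc1Br` gives 24.3 nM in this assay, and compound 2 `COc1ccc(S(=O)(=O)CCCN2CCC(CCC(=O)c3cc(Cl)c(N)cc3OC)CC2)cc1` gives 12.2 nM in this assay. Of these two numbers, compound 1 has the higher one, but the gap to compound 2 is within the usual scatter, so the two values cannot be told apart with confidence.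

Compound 3 `COc1cc(N)c(Cl)cc1C(=O)CCC1CCN(CCNS(=O)(=O)c2ccc(N)cc2)CC1` has not yet been measured in this assay. It differs from compound 1 in one place: 4-aminophenyl in place of 3-bromo-4-methoxyphenyl on a sulfonyl sulfur. Within the data shown here, no pair of measured compounds shows what this kind of replacement does on the shared core, so the size and direction of the step can only be estimated. A modest step toward a higher number, roughly at the edge of the scatter, is expected from compound 1 to compound 3 in this assay, a 1.6-fold higher number from compound 1 to compound 3 (0.22 log units; within the scatter). On that basis compound 3 is expected to give about 40 nM in this assay, with a likely range from 10 nM to 160 nM.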

Compound 3, inhibition constant: 1.97 nM
Compound 3: the middle estimate sits 20-fold (1.31 log units) above what was measured, outside the stated range (below it).
By their numbers in this assay, from the lowest: compound 3; then compounds 2 and 1 (each within the scatter of the next).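

On the sulfonyl sulfur of the shared core, in this assay, 4-aminophenyl in place of 3-bromo-4-methoxyphenyl gives a 12-fold lower number from compound 1 to compound 3 (1.09 log units; beyond the scatter) and so counts as a large step. Among these compounds, the earlier compounds offered no step in a single place, so this is the first sign that the group on this sulfonyl sulfur can move the read-out well beyond the scatter. Nothing measured here gives a reason for the size or direction of this step.

The change removes the bromine and the methoxy group and adds the amine all at once, so the compounds shown leave open which of these parts carries the step. A plain phenyl group on the same sulfonyl sulfur, or an acetamide in place of the amine, would help to separate those contributions.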